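The compounds below may be only part of what the source reports. "The series", "measured", "known", "first", "only" and "open" are said of these compounds alone.

Series notes, solubility. Compound 1 `COc1ccccc1-c1nc(C)c(COc2ccccc2C(=O)O)o1` and compound 2 `COc1cccc(-c2nc(C)c(COc3ccccc3C(=O)O)o2)c1` share one core; compound 3 `COc1ccccc1-c1nc(C)c(COc2ccc(CC(=O)O)cc2)o1` and compound 4 `COc1cccc(-c2nc(C)c(COc3ccc(CC(=O)O)cc3)o2)c1` share another. The difference between the two cores is not broken down here. In a physicochemical assay for solubility, tested at 500 uM (on this read-out lower numbers stand for lower solubility and higher numbers for higher solubility), compound 1 gives 402000 nM, compound 2 gives 264000 nM and compound 3 gives 436000 nM; compound 4 is not yet measured. The three measured values lie within the scatter of one another, so no order among them is claimed.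

The change from compound 1 to compound 2 is 3-methoxyphenyl in place of 2-methoxyphenyl on an aromatic carbon, and it gave a 1.5-fold lower number from compound 1 to compound 2 (0.18 log units; within the scatter). The change from compound 3 to compound 4 is 3-methoxyphenyl in place of 2-methoxyphenyl on an aromatic carbon; its place is the same word for word, so it is the same change made on the other core. It occurs twice among the compounds here, once measured and once not.

Expectation. Among the compounds with values here, the one measured instance of the change left the number within the scatter, and nothing else here speaks to this change. The expected step is a 1.5-fold lower number from compound 3 to compound 4 (0.16 log units; within the scatter), a small move of the same direction and size as the measured one. For compound 4 the estimate in this assay is 300000 nM, expected to fall between 180000 nM and 460000 nM. The expectation rests on a single measured step, so the range is kept wide. The measured numbers also sit close to the concentration at which the assay is run, so a limit rather than a number remains possible for compound 4.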

Compound 4, solubility: 410000 nM
Beside the measured number, compound 4's estimate is 1.4-fold (0.14 log units) below it; the range from low to high includes it.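

In this assay, 3-methoxyphenyl in place of 2-methoxyphenyl gives a 1.1-fold lower number from compound 3 to compound 4 (0.03 log units; within the scatter), and the same change on the other core gives a 1.5-fold lower number from compound 1 to compound 2 (0.18 log units; within the scatter), so on both cores the step stays within the scatter. This shows that, for these two cores, the change can be carried from one to the other without a step beyond the scatter appearing; it does not show a shared effect of the change, since two steps within the scatter fix neither a direction nor a size, and one pair on each of two cores is a narrow base for any wider rule. No supporting information bears on how the step reads on either core.

The compounds shown carry only a methoxy group on this phenyl ring, so it stays open whether the change of place would read the same way for an amine or a nitrile there. Also open, from the compounds shown here alone, is how a longer chain ending in the carboxylic acid would read on either core, and whether a step beyond the scatter would carry from one core to the other.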